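The source may hold more compounds than are shown below. What is called first, only, known or untested is meant among the compounds shown, and "the series" means these compounds.

Measured compounds:
compound 1 `CCOC(=O)C1=Cc2ccccc2OC1(OCc1cn(CC(=O)Nc2ccc(C)cc2)nn1)C(F)(F)F` — in a functional assay on MCF7 cells (Homo sapiens) for inhibition, read by MTT assay, with a stated time of 24 h (on this read-out lower numbers stand for stronger inhibition and higher numbers for weaker inhibition), compound 1 gives > 150000 nM, a limit of the assay and not a number.
compound 2 `CCOC(=O)C1=Cc2ccccc2OC1(OCc1cc(-c2ccc(Br)cc2)no1)C(F)(F)F` — in this assay compound 2 gives > 150000 nM, again only a limit.

Where compound 1 stands: no number is known for compound 1 in this assay, only the limit at which it sits. Compound 2 sits at the same limit, so the two cannot be ordered against each other. Both values shown lie at the limit of > 150000 nM in this assay, at which 2 of the 2 values shown sit. For the measured compounds named here, no step between measured compounds can be drawn from this pair; it shows only that both compounds fall outside the reach of this assay.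

Compound 3 `CCOC(=O)C1=Cc2ccccc2OC1(OCc1cn(CC(=O)Nc2ccccc2F)nn1)C(F)(F)F` differs from compound 1 by 2-fluorophenyl in place of 4-methylphenyl on an amide-type nitrogen — in words, 2-fluorophenyl in place of 4-methylphenyl on an amide-type nitrogen. Nothing measured in the series resolves a change of this kind. Since compound 1 sits at the limit > 150000 nM, compound 3 is expected to return a limit as well. The step from compound 1 to compound 3 is expected to be a step that the limit leaves unreadable from compound 1 to compound 3, none beyond the scatter. Compound 3 is estimated at 200000 nM in this assay, with a range from 100000 nM to 500000 nM.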

Compound 3, half-maximal inhibitory concentration: 42100 nM
Compound 3: the middle estimate sits 4.8-fold (0.68 log units) above what was measured; the measured number lies below the stated range.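

In this assay, for the compounds shown here, compound 3 gives 42100 nM and so provides the only number among the values shown, which makes the aryl group on the amide-type nitrogen a position where a single change can bring the series within reach of the read-out. Placing 2-fluorophenyl in place of 4-methylphenyl on that nitrogen gives an at least 3.5-fold lower number from compound 1 to compound 3 (0.55 log units; beyond the scatter) and this step is a floor rather than a measured size. The limit still governs most of the series, so compound 3 stands alone as a measured point: the limit of > 150000 nM in this assay, at which 2 of the 3 values shown sit.

The change removes the methyl group and adds the fluorine at once, and it also alters where the ring carries its substituent, so the compounds shown do not tell which of these accounts for the step. On these data alone, how a plain phenyl or a cyclohexyl on the same amide-type nitrogen would read remains open, as does whether the same change would bring a number on the shared core with another group in place of the amide side chain.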